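Swapping Phenyl for Thiophene on the Strongest Compound

This account rests on a few compounds, and the source may have more. Where it says the series, first, only, none or still open, it means among the compounds named here.

So far, three compounds have been tested in a functional assay on the whole organism (plasma, strain Sprague-Dawley) with Rattus norvegicus as the target, with a stated time of 2 h, at a dose of 100 mg/kg by the oral route; on this read-out lower numbers stand for a weaker effect and higher numbers for a stronger effect at the one dose given. Compound 2 `c1ccc(C(/N=C2\CCCCCCN2)C2CC2)cc1` gives 58% and stands highest of the three numbers. Compound 1 `c1ccc(C(/N=C2\CCCCN2)C2CC2)cc1` gives 36% in this assay, which lies beyond the scatter below compound 2. Compound 3 `c1ccc2c(C(/N=C3\CCCCCN3)C3CC3)cccc2c1` gives 21% in this assay, further still below compound 2 and also beyond the scatter. No two of these three compounds differ in only one place, so their numbers can be read side by side but no single change can be tied to a single step.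

Compound 4 `c1csc(C(/N=C2\CCCCCCN2)C2CC2)c1` has not yet been measured. It differs from compound 2 in one place: thiophen-2-yl in place of phenyl on a saturated chain carbon bound to a double-bonded nitrogen and a saturated ring carbon. Among the compounds with values here, no measured pair in this set shows what this particular change does, so any expectation must rest on the value of compound 2 alone.

Because compound 2 gives 58% in this assay, compound 4 is expected to land near that figure, with the step from compound 2 to compound 4 estimated at a number 8 percentage points lower from compound 2 to compound 4 (within the scatter), a size that would sit within the scatter of repeated measurements. The estimate for compound 4 in this assay is 50%, with a range from 30% to 70%.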

Compound 4, a percentage reported as inhibition, in the whole organism at one dose (the size of the read-out at that dose, not a potency): 50%
Estimate against measurement, compound 4: no gap at the digits printed, within the range that was stated.
By their numbers in this assay, from the lowest: compound 3; then compound 1; then compounds 4 and 2 (each within the scatter of the next).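

In this assay, within the data shown here, the exchange of phenyl for thiophen-2-yl gives a number 8 percentage points lower from compound 2 to compound 4 (within the scatter) and is the first change in this set that can be read at a single place. At this one dose, the two compounds cannot be told apart. The position on a saturated chain carbon bound to a double-bonded nitrogen and a saturated ring carbon can therefore carry a five-membered aromatic ring with one sulfur atom instead of a six-membered aromatic ring of carbon only, with no difference beyond the scatter, and no measurement here explains that result.

This single pair cannot show how other groups behave at this position, such as a furan-2-yl ring, a pyridin-2-yl ring or a phenyl ring carrying an amine. Going by these compounds, the read-out also comes from one dose at one stated time and is not a potency, so it remains open whether compound 2 and compound 4 would stay this close at other doses or times.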